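Chloro on the Aromatic Ring in Two Ester Series

This account rests on a few compounds, and the source may have more. Where it says the series, first, only, none or still open, it means among the compounds named here.

Compound 1 `COC(=O)C1=C(C)N(c2ccccc2)C=C(C)C1c1ccccc1` gives -48% in a functional assay, tested at 200 ug/mL; on this read-out higher numbers stand for a weaker effect at the one concentration tested and lower numbers for a stronger effect.
Compound 2 `COC(=O)C1=C(C)N(c2cccc(Cl)c2)C=C(C)C1c1ccccc1` gives -35.3%.
Compound 3 `CC1=C(C(=O)OC(C)(C)C)C(c2ccccc2)C=CN1c1ccccc1` gives -52.9%.

Compound 1 and compound 2 differ by one change, (chloro in place of hydrogen on an aromatic carbon), and this produced a number 12.7 percentage points higher from compound 1 to compound 2 (beyond the scatter). Compound 3 carries a different core; how it differs from compound 1 is not broken down here. The values of compound 3 and compound 1 lie within the scatter of each other, while the value of compound 2 stands beyond the scatter above that of compound 3.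

Compound 4 `CC1=C(C(=O)OC(C)(C)C)C(c2ccccc2)C=CN1c1ccc(Cl)cc1` is not yet measured. It differs from compound 3 by chloro in place of hydrogen on an aromatic carbon. This is the same kind of change as that from compound 1 to compound 2, but the place is not identical: there the chloro sat meta to a large group, here it sits para to a large group. For the measured compounds named here, the only precedent is the modest rise seen in a number 12.7 percentage points higher from compound 1 to compound 2 (beyond the scatter), so a step of similar size is expected, a number 12.9 percentage points higher from compound 3 to compound 4 (beyond the scatter). On that basis compound 4 is estimated at -40%, between -55% and -25%.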

Compound 4, a percentage reported as activity, at one concentration (the size of the read-out at that concentration, not a potency): -48%
Beside the measured number, compound 4's estimate is 8 percentage points above it, within the range that was stated.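

Placing chloro on the aromatic ring of the second core gave, in this assay, a number 4.9 percentage points higher from compound 3 to compound 4 (within the scatter), so on this core the change produced no shift that can be told from the scatter. Set beside the earlier step, this result does not differ from it by more than repeated measurements allow: the same change on two cores in this assay, a number 12.7 percentage points higher (beyond the scatter) from compound 1 to compound 2 and a number 4.9 percentage points higher (within the scatter) from compound 3 to compound 4, 7.8 percentage points apart, within the scatter of two such steps. For the compounds shown here, the two steps are therefore compatible with one shared effect of the change across both cores, but they do not establish it, as there are only two pairs, only one step lies beyond the scatter, and the chloro does not sit in the same place in both, so core and place cannot be separated.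

On these data alone, it remains open how a fluoro, a methoxy or a nitrile would read in the place the chloro holds in compound 4, para to a large group. Also open, as far as these compounds go, is how an amide or a carboxylic acid would read in place of the ester on either core.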